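This account rests on a few compounds, and the source may have more. Where it says the series, first, only, none or still open, it means among the compounds named here.

Compound 1, whose structure is `O=C1N=C(N2N=C(c3ccccc3)CC2c2ccccc2O)S/C1=C1/C(=O)Nc2ccccc21`, was tested in a functional assay on cells (Cancer cell lines, Homo sapiens) for cytotoxicity, read by sulforhodamine B assay, with a stated time of 48 h (a higher number here means a weaker inhibitor of growth, a lower number a stronger inhibitor of growth), where compound 1 gives 2090 nM. Compound 2, with the structure `O=C1N=C(N2N=C(c3ccccc3)CC2c2ccccc2O)S/C1=C1/C(=O)Nc2ccc(Br)cc21`, differs from compound 1 by a single change: bromo in place of hydrogen on an aromatic carbon. In this assay compound 2 gives 260 nM, so that this change made a step of an 8.0-fold lower number from compound 1 to compound 2 (0.91 log units; beyond the scatter).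

Compound 3, with the structure `COc1ccc(C2=NN(C3=NC(=O)/C(=C4\C(=O)Nc5ccccc54)S3)C(c3ccc(OC)cc3)C2)cc1`, is built on a different core; the difference between the two cores is not broken down here. In this assay compound 3 gives 81500 nM, the highest of the three numbers, which places it well behind both compound 1 and compound 2.

Compound 4, whose structure is `COc1ccc(C2=NN(C3=NC(=O)/C(=C4\C(=O)Nc5ccc(Br)cc54)S3)C(c3ccc(OC)cc3)C2)cc1`, has not yet been measured. It differs from compound 3 by bromo in place of hydrogen on an aromatic carbon, the same change, at the same place, that turned compound 1 into compound 2. Among the measured compounds shown here, because that earlier step was an 8.0-fold lower number from compound 1 to compound 2 (0.91 log units; beyond the scatter), the same change on the core of compound 3 is expected to lower the number as well, though a single example gives no certainty that a step of the same size carries over to a different core, so a somewhat smaller step of a 5.4-fold lower number from compound 3 to compound 4 (0.74 log units; beyond the scatter) is estimated. On that basis compound 4 is expected to give about 15000 nM in this assay, with the estimate reasonably placed between 4000 nM and 60000 nM.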

Compound 4, concentration for 50% growth inhibition: 210 nM
Compound 4: middle estimate off by 71-fold (1.85 log units), on the high side; the measured number lies below the stated range.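

In this assay, bromo in place of hydrogen on an aromatic carbon gave a 390-fold lower number from compound 3 to compound 4 (2.59 log units; beyond the scatter), so the change lowered the number on the core of compound 3, as it had on the core of compound 1. The direction of the step carried over from one core to the other, but its size did not: the same change on two cores in this assay, an 8.0-fold lower number (0.91 log units; beyond the scatter) from compound 1 to compound 2 and a 390-fold lower number (2.59 log units; beyond the scatter) from compound 3 to compound 4, 48-fold (1.68 log units) apart, beyond the scatter of two such steps. These two pairs show that a step measured on one core in this series is a poor guide to the size of the same step on another; they do not show why the two steps differ, and two cores give no rule for how large the step would be on a third.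

As far as these compounds go, whether a chlorine, a fluorine or an amine on that same aromatic carbon would lower the number as bromo does remains open on both cores. From the compounds shown here alone, the two cores also differ in more than one place, and which of those differences sets the size of the step stays open too.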